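The compounds below may be only part of what the source reports. "The series", "measured", "known", "first", "only" and "open" are said of these compounds alone.

Compound 2 `COc1cc(C(=O)Nc2nn[nH]n2)nc(-c2ccc(C(C)C)cc2)c1` gives 54% in a functional assay on the whole organism with Rattus norvegicus as the target, at a dose of 1 mg/kg by the oral route (on this read-out lower numbers stand for a weaker effect and higher numbers for a stronger effect at the one dose given), the higher of the two numbers in hand. For the measured compounds named here, its one comparator, compound 1 `CCc1ccc(-c2cc(OC)cc(C(=O)Nc3nn[nH]n3)n2)cc1`, gives 43% in this assay, and the single measured step, a number 11 percentage points higher from compound 1 to compound 2 (beyond the scatter), comes from a methyl in place of hydrogen on a saturated chain carbon bound to an aromatic carbon and a saturated chain carbon. Compound 3 `COc1cc(C(=O)Nc2nn[nH]n2)nc(-c2ccc(NC(C)=O)cc2)c1` is not yet measured. It differs from compound 2 in one place: acetamido in place of isopropyl on an aromatic carbon. Going by the values given here, no measured step concerns an exchange of this kind, since the only step in hand changes one alkyl group into another, whereas here an alkyl group is replaced by an acetamido group that brings a hydrogen-bond donor and a hydrogen-bond acceptor. The step from compound 1 to compound 2 therefore gives no direction for the present change, and the expectation rests on little more than the level of compound 2 itself. The estimate for compound 3 in this assay is 40%, within 15% to 65%. That estimate means an expected step of a number 14 percentage points lower from compound 2 to compound 3 (beyond the scatter), with its sign uncertain.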

Compound 3, a percentage reported as inhibition, in the whole organism at one dose (the size of the read-out at that dose, not a potency): 0%
Compound 3: middle estimate off by 40 percentage points, on the high side; the whole stated range lies above it.
By their numbers in this assay, from the lowest: compound 3; then compound 1; then compound 2.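

In this assay, the earlier compounds had shown only one alkyl group exchanged for another at this aromatic carbon, para to a large group, and the acetamido group now shows that the position does not tolerate every substituent, giving a number 54 percentage points lower from compound 2 to compound 3 (beyond the scatter) and a number 43 percentage points lower from compound 1 to compound 3 (beyond the scatter) in the two comparisons. The ethyl and isopropyl groups both leave a clear effect at the one dose given, whereas with the acetamido group compound 3 gives 0%, so the choice of group at this carbon can decide whether any effect is seen at all. Nothing measured here accounts for this loss.

The compounds shown leave open whether the loss belongs to the acetamido group as a whole or to one of its parts, and a plain amine or a propyl chain at the same carbon would begin to separate the amide hydrogen and the carbonyl from the size of the group. They also leave open whether the rise from ethyl to isopropyl continues with a tert-butyl group, and whether a carboxylic acid here would behave like the acetamido group.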